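Adenosine triphosphate iodoacetamide probes against hexokinase-1

The source may report more compounds than this note shows. Statements on the series, on what has been measured and on what is new or still open speak of the compounds shown alone.

Measured compounds:
compound 1, `CN(CCCCN(C)c1ncnc2c1ncn2[C@@H]1O[C@H](COP(=O)(O)OP(=O)(O)OP(=O)(O)O)[C@@H](O)[C@H]1O)C(=O)CCCNC(=O)CI`: 0%
compound 2, `O=C(CI)NCCCCNc1ncnc2c1ncn2[C@@H]1O[C@H](COP(=O)(O)OP(=O)(O)OP(=O)(O)O)[C@@H](O)[C@H]1O`: 0%
compound 3, `O=C(CI)NCCNc1ncnc2c1ncn2[C@@H]1O[C@H](COP(=O)(O)OP(=O)(O)OP(=O)(O)O)[C@@H](O)[C@H]1O`: 0%

All three measured compounds share a triphosphorylated nucleoside core bearing an iodoacetamide-terminated side chain on the aromatic amine. In an assay on isolated protein for inhibition of hexokinase-1 (Rattus norvegicus), with a stated time of 6 h, tested at 10 mM (on this read-out lower numbers stand for less inhibition and higher numbers for more inhibition at the one concentration tested (going by the name of the read-out)), compound 1 gives 0%, compound 2 gives 0% and compound 3 gives 0%. None of the three shows measurable inhibition at the single concentration tested.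

Compounds 3 and 2 differ in one place only: 2-(((iodomethyl)carbonyl)amino)ethyl in place of ((iodomethyl)carbonyl)amino on a saturated chain carbon, two bonds along the chain from a nitrogen on an aromatic ring. The step of no change at the digits printed from compound 3 to compound 2 (within the scatter) lies within the usual scatter, so lengthening the chain between the aromatic amine and the iodoacetamide has no detectable effect on this read-out. Compound 1 and compound 3 differ in more than one place; the difference between their cores is not broken down here. Compound 1 stands level with compounds 2 and 3 at the digits reported.

Compound 4, `CN(CCCCN(C)c1ncnc2c1ncn2[C@@H]1O[C@H](COP(=O)(O)OP(=O)(O)OP(=O)(O)O)[C@@H](O)[C@H]1O)C(=O)CCCCCNC(=O)CI`, is not yet measured. It differs from compound 1 by 2-(((iodomethyl)carbonyl)amino)ethyl in place of ((iodomethyl)carbonyl)amino on a saturated chain carbon, three bonds along the chain from a carbonyl carbon. Going by the values given here, this is the same kind of change as the one from compound 3 to compound 2, but the place is not identical: in the earlier pair the chain grows two bonds along from a nitrogen on an aromatic ring, whereas here it grows three bonds along the chain from a carbonyl carbon. Because the earlier step of no change at the digits printed from compound 3 to compound 2 (within the scatter) produced no change, the expected step of no change at the digits printed from compound 1 to compound 4 (within the scatter) is also no change. Compound 4 is thus expected to give 0% in this assay, with a range of 0% to 10%, resting on compound 1 at 0% and on the flat step seen between compounds 3 and 2.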

Compound 4, a percentage reported as inhibition, at one concentration (the size of the read-out at that concentration, not a potency): 0%
Compound 4: the middle estimate sits on the measured number at the digits printed; the range from low to high includes it.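

In this assay, putting 2-(((iodomethyl)carbonyl)amino)ethyl in place of ((iodomethyl)carbonyl)amino on a saturated chain carbon, three bonds along the chain from a carbonyl carbon, gives no change at the digits printed from compound 1 to compound 4 (within the scatter). Set beside the earlier pair, the same chain extension reads alike on the two cores: the same change on two cores in this assay, no change at the digits printed (within the scatter) from compound 3 to compound 2 and no change at the digits printed (within the scatter) from compound 1 to compound 4, 0 percentage points apart, within the scatter of two such steps This shows only that the extension leaves the read-out flat on both cores at the one concentration tested; with no inhibition seen on any of the four compounds, it does not show that the change would stay silent on a core with measurable inhibition, or that a step of real size would carry from one core to another.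

Still open, going by these compounds, is whether a longer chain, or a chloroacetamide or acrylamide end in place of the iodoacetamide, would bring any inhibition into this assay. Also open, on these data alone, is how far the separate differences between the core of compound 1 and the core of compound 3 matter, as those two compounds differ in more than one place.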